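A few compounds are considered here, and "the series" means these few. Any claim that something is new, unique, unknown or untested is made for them only; others in the source may bear on it.

Compound 1: `Cc1ccc2[nH]c(=O)c(CN(Cc3ccc(OCC(=O)OC(C)(C)C)cc3)Cc3ccc(C(C)(C)C)cc3)cc2c1` — > 10000 nM
Compound 2: `CCCCOc1ccc(CN(Cc2ccc(C(C)(C)C)cc2)Cc2cc3cc(C)ccc3[nH]c2=O)cc1` — > 5000 nM

Compound 1 carries the structure `Cc1ccc2[nH]c(=O)c(CN(Cc3ccc(OCC(=O)OC(C)(C)C)cc3)Cc3ccc(C(C)(C)C)cc3)cc2c1`. In a toxicity assay on MDCK cells (Canis lupus familiaris) for cytotoxicity, read by crystal violet staining, with a stated time of 48 h (a lower number here means that less compound is tolerated, a higher number that more compound is tolerated), compound 1 gives > 10000 nM, a limit of the assay rather than a number. Compound 2 carries the structure `CCCCOc1ccc(CN(Cc2ccc(C(C)(C)C)cc2)Cc2cc3cc(C)ccc3[nH]c2=O)cc1`. In this assay compound 2 gives > 5000 nM, which is likewise a limit and not a number, so compound 2 stands at a limit, as does the only other compound shown. Going by the values given here, the single step between them, a step that the two limits leave unreadable from compound 1 to compound 2, is left unreadable by the two limits the limit of > 10000 nM in this assay, at which 1 of the 2 values shown sits, and (the limit of > 5000 nM in this assay, at which 1 of the 2 values shown sits).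

Compound 3 has the structure `Cc1ccc2[nH]c(=O)c(CN(Cc3ccc(C(C)(C)C)cc3)[C@H](CO)c3ccccc3)cc2c1`. It differs from compound 2 by 2-hydroxy-1-phenylethyl in place of 4-butoxybenzyl on an amine nitrogen. Among the compounds with values here, no measured step bears readably on this change, and both values shown are limits. Compound 3 is therefore expected to show a step that the limit leaves unreadable from compound 2 to compound 3, no step beyond the scatter. Compound 3 is estimated at 8000 nM, with a range of 3000 nM to 30000 nM.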

Compound 3, half-maximal cytotoxic concentration: > 10000 nM
Compound 3 ended at the assay's limit; the forecaster's own chance of this, stated with the estimate: 80%; middle value at least 1.2-fold (0.09 log units) away from the limit.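

In this assay compound 3 gives > 10000 nM, a limit of the assay and not a number. Going by these compounds alone, compound 2 and compound 3 both stand at limits, and no step between them can be read. On these data alone, the concentration at which any of the three compounds becomes cytotoxic remains open.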